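Ethyl to propyl on the core: a small extension

The source may hold more compounds than are shown below. What is called first, only, known or untested is meant among the compounds shown, and "the series" means these compounds.

Compound 2 `CCn1c(-c2ccccc2)nc2c(N)ncnc21` and compound 1 `CCn1c(-c2ccccc2)nc2c(NC3CCCC3)ncnc21` share a core and differ only in that compound 2 carries hydrogen where compound 1 carries cyclopentyl on a nitrogen on an aromatic ring. In a functional assay on CHO cells for antagonist activity at adenosine receptor A2b (Homo sapiens), read by 33P incorporation, with a stated time of 20 min (on this read-out lower numbers stand for stronger inhibition and higher numbers for weaker inhibition), compound 1 gives 5790 nM, and compound 2 gives 3020 nM. The step of a 1.9-fold lower number from compound 1 to compound 2 (0.28 log units; within the scatter) stays inside the scatter, so the two numbers cannot be told apart, and compound 2 has no claim to being stronger or weaker than compound 1.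

Compound 3 `CCCn1c(-c2ccccc2)nc2c(N)ncnc21` is not yet measured. It differs from compound 2 in one place: methyl in place of hydrogen on a saturated chain carbon, two bonds along the chain from an aromatic nitrogen.

Within the data shown here, the only measured step concerns a different nitrogen and a different group, so no measured step bears directly on this change. Among the measured compounds shown here, the one step available, a 1.9-fold lower number from compound 1 to compound 2 (0.28 log units; within the scatter), was itself within the scatter. With nothing to suggest a move in either direction, no step beyond the scatter is expected in this assay, and compound 3 is estimated at 3000 nM with a range from 1000 nM to 9000 nM, meaning an expected step of a 1.0-fold lower number from compound 2 to compound 3 (0.00 log units; within the scatter).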

Compound 3, inhibition constant: 1040 nM
Beside the measured number, compound 3's estimate is 2.9-fold (0.46 log units) above it; the measured number falls inside the stated range.
By their numbers in this assay, from the lowest: compound 3; then compounds 2 and 1 (each within the scatter of the next).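

In this assay, among these compounds, ethyl to propyl on the aromatic nitrogen gives the first step in this small set that lies beyond the scatter: a 2.9-fold lower number from compound 2 to compound 3 (0.46 log units; beyond the scatter). The size is modest, but it shows that this chain can register the addition of a single methyl, two bonds along from the aromatic nitrogen, with compound 3 giving stronger inhibition than compound 2, whereas the earlier exchange of cyclopentyl for hydrogen on the other nitrogen, a 1.9-fold lower number from compound 1 to compound 2 (0.28 log units; within the scatter), could not be read as a change at all. Nothing available explains why this added methyl lowers the number.

This is still a single pair, so it cannot show whether the trend continues with a longer chain such as butyl or holds for a branched group such as isopropyl. It also leaves open whether a polar end group on the chain, such as an amine or a carboxylic acid, would keep the lower number, and whether propyl would give a similar step with cyclopentyl on the other nitrogen.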